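The source may hold more compounds than are shown below. What is called first, only, known or untested is meant among the compounds shown, and "the series" means these compounds.

Among the measured compounds shown here, compound 2, with structure `C=C1C(=O)[C@]23C[C@@]1(O)CC[C@H]2c1ccc(O)c(C)c1[C@@H]3Cn1cc(-c2ccccc2)nn1`, is the only compound that gives a number in a functional assay on MCF7 cells (Homo sapiens) for cytotoxicity, read by MTT assay, with a stated time of 4 days (on this read-out lower numbers stand for stronger inhibition and higher numbers for weaker inhibition), where compound 2 shows 1740 nM. Compound 1, structure `C=C1C[C@]23C[C@@]1(O)CC[C@H]2c1ccc(OS(=O)(=O)c2ccc(C)cc2)c(C)c1[C@@H]3Cn1cc(-c2ccc(Cl)cc2)nn1`, differs from compound 2 in several places at once. In this assay compound 1 reaches only > 20000 nM, which is a limit rather than a number. Compound 3, structure `C=C1C(=O)[C@]23C[C@@]1(O)CC[C@H]2c1ccc(O)c(C)c1[C@@H]3Cn1cc(-c2ccc(OC)cc2)nn1`, carries a single change from compound 2: methoxy in place of hydrogen on an aromatic carbon. For the measured compounds named here, with no measured pair of this kind to draw on, the step from compound 2 to compound 3 is expected to stay within the scatter, a 1.1-fold lower number from compound 2 to compound 3 (0.04 log units; within the scatter). Compound 3 is therefore estimated at 1600 nM, between 500 nM and 5000 nM.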

Compound 3, half-maximal inhibitory concentration: 1710 nM
Compound 3: the middle estimate sits 1.1-fold (0.03 log units) below what was measured; measured number inside the range.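

In this assay, the change from phenyl to 4-methoxyphenyl gives a 1.0-fold lower number from compound 2 to compound 3 (0.01 log units; within the scatter) and so leaves the read-out where it was. Among the compounds shown here, this is the only comparison here between compounds that differ in one place, and it shows that this aromatic carbon, para to a large group, accepts methoxy in place of hydrogen without a readable shift. Nothing among the data shown bears on why this is so. Still open, from the compounds shown here alone, is whether an amine or a carboxylic acid at this position would move the number. A longer chain such as butoxy in place of methoxy is equally untested here.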